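This account rests on a few compounds, and the source may have more. Where it says the series, first, only, none or still open, it means among the compounds named here.

The measured compounds:
compound 1 `CN(c1ccnc(Nc2ccc(C#N)cc2)n1)c1c(F)cc(-c2ccc(C#N)cc2)cc1F` gives 148000 nM in an ADME assay on MT4 cells (Homo sapiens) for cytotoxicity, read by MTT assay, with a stated time of 5 days; a higher number here means that more compound is tolerated, a lower number that less compound is tolerated
compound 2 `CC(C)CN(c1ccnc(Nc2ccc(C#N)cc2)n1)c1c(F)cc(-c2ccc(C#N)cc2)cc1F` gives 241000 nM
compound 3 `N#Cc1ccc(Nc2nccc(N(CCCCl)c3c(F)cc(-c4ccc(C#N)cc4)cc3F)n2)cc1` gives > 250000 nM, which is a limit of the assay rather than a number

For compound 3 only a limit is known: it sits at the limit of > 250000 nM in this assay, at which 1 of the 3 values shown sits, so its true value is not pinned down. Compound 4 `CC(=O)N(c1ccnc(Nc2ccc(C#N)cc2)n1)c1c(F)cc(-c2ccc(C#N)cc2)cc1F` differs from it by acetyl in place of 3-chloropropyl on a nitrogen on an aromatic ring. The measured steps that end at compound 3 are an at least 1.6-fold higher number from compound 1 to compound 3 (0.22 log units; that floor lies within the scatter) and an at least 1.0-fold higher number from compound 2 to compound 3 (0.01 log units; that floor lies within the scatter), and a 1.6-fold higher number from compound 1 to compound 2 (0.21 log units; within the scatter) shows that exchanging one saturated chain for another also changed little. None of these steps brings in an acetyl, so the step to compound 4 is expected to stay within the scatter, an at least 1.1-fold lower number from compound 3 to compound 4 (0.05 log units; that floor lies within the scatter). Compound 4 is therefore estimated at 220000 nM in this assay, with a range from 110000 nM to 400000 nM.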

Compound 4, half-maximal cytotoxic concentration: > 268000 nM
Compound 4: only a limit was reported; the forecaster's own chance of this, stated with the estimate: 45%; at least 1.2-fold (0.08 log units) between middle value and limit.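

In this assay compound 4 gives > 268000 nM, which is a limit of the assay. So this nitrogen on an aromatic ring carries an acetyl, not only a saturated chain, with no sign that less compound is tolerated: the steps are an at least 1.1-fold higher number from compound 2 to compound 4 (0.04 log units; that floor lies within the scatter) and an at least 1.8-fold higher number from compound 1 to compound 4 (0.25 log units; that floor lies within the scatter). The step from compound 3 to compound 4 cannot be read, since both values are limits.

As far as these compounds go, the true value of compound 4 stays unknown. From the compounds shown here alone, whether an amine or a carboxylic acid at this nitrogen would lower the tolerated concentration also remains open.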